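Acetoxy in place of the sulfur-bearing group on compound 3

This account rests on a few compounds, and the source may have more. Where it says the series, first, only, none or still open, it means among the compounds named here.

Compound 3 `Cc1nc2c(OCc3ccccc3)cccn2c1C[S+](C)[O-]` gives 0% in a functional assay on the whole organism with Rattus norvegicus as the target, with a stated time of 4 h, at a dose of 40 mg/kg by the intraperitoneal route (a higher number here means more inhibition at the dose given (going by the name of the read-out), a lower number less inhibition), the lowest of the three numbers measured. Compound 1 `Cc1nc2c(OCc3ccccc3)cccn2c1C#N` gives 25% in this assay, and compound 2 `CCOCc1c(C)nc2c(OCc3ccccc3)cccn12` gives 84% in this assay. The measured steps are a number 25 percentage points lower from compound 1 to compound 3 (beyond the scatter) and a number 84 percentage points lower from compound 2 to compound 3 (beyond the scatter). Compound 4 `CC(=O)OCc1c(C)nc2c(OCc3ccccc3)cccn12` differs from compound 3 by a group of 4 heavy atoms (2 carbon, 2 oxygen; no ring) in place of a group of 3 heavy atoms (1 carbon, 1 oxygen, 1 sulfur; no ring), on a saturated chain carbon bound to an aromatic carbon. The step that bears on this change is a number 84 percentage points lower from compound 2 to compound 3 (beyond the scatter), a change at the same saturated chain carbon bound to an aromatic carbon; compound 2 carries an ethoxymethyl there, and its ether oxygen is closer in kind to the acetoxy of compound 4 than the sulfur-bearing group of compound 3. A large rise in this assay is therefore expected, though acetoxy is not ethoxymethyl, so the estimate stays under the value of compound 2. Compound 4 is expected to give 60%, range 30% to 85%, an expected step of a number 60 percentage points higher from compound 3 to compound 4 (beyond the scatter).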

Compound 4, a percentage reported as inhibition, in the whole organism at one dose (the size of the read-out at that dose, not a potency): 88%
The estimate for compound 4 lay 28 percentage points below the measured number, and the stated range ends below it.
By their numbers in this assay, from the lowest: compound 3; then compound 1; then compounds 2 and 4 (each within the scatter of the next).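

In this assay acetoxy in place of the sulfur-bearing group gives a number 88 percentage points higher from compound 3 to compound 4 (beyond the scatter) and acetoxymethyl in place of cyano gives a number 63 percentage points higher from compound 1 to compound 4 (beyond the scatter) on the shared core. With a number 4 percentage points higher from compound 2 to compound 4 (within the scatter) for acetyl in place of ethyl on the oxygen, this read-out does not separate the ester from the ether on this saturated chain carbon. No measurement on hand accounts for these steps.

From the compounds shown here alone, whether a free hydroxyl, an amine or a longer ether chain on the same carbon would hold the read-out remains open. A single dose and time also leave the potency of the ester and the ether unresolved.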